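Phenyl for furan-2-yl: what happens to compound 2?

This account rests on a few compounds, and the source may have more. Where it says the series, first, only, none or still open, it means among the compounds named here.

In a functional assay on HCT-15 cells (Homo sapiens) for antiproliferative activity (a higher number here means a weaker inhibitor, a lower number a stronger inhibitor), compound 1 (`COc1ccc(S(=O)(=O)Oc2ccccc2NC(=O)Nc2ccccc2)cc1`) gives > 10000 nM as a limit of the assay. Among the compounds with values here, compound 2 (`COc1ccc(S(=O)(=O)Oc2ccccc2NC(=O)c2ccco2)cc1`) gives 19 nM as the only true number so far. Changing the group on the carbonyl carbon gave an at least 520-fold lower number from compound 1 to compound 2 (2.72 log units; beyond the scatter) and so this place clearly matters. Compound 3 (`COc1ccc(S(=O)(=O)Oc2ccccc2NC(=O)c2ccccc2)cc1`) has phenyl in place of furan-2-yl on a carbonyl carbon. That earlier step removed anilino, whereas here one aromatic ring replaces another, so compound 3 is expected to stay fairly near compound 2 at 19 nM in potency. A modest move toward a weaker inhibitor is expected in this assay as a 2.6-fold higher number from compound 2 to compound 3 (0.42 log units; beyond the scatter) overall. Compound 3 is estimated at 50 nM within an expected range from 10 nM to 300 nM in this read-out.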

Compound 3, half-maximal inhibitory concentration: 310 nM
Compound 3: middle estimate off by 6.2-fold (0.79 log units), on the low side; the measured number lies above the stated range.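

In this assay, replacing one aromatic ring with another on the carbonyl carbon proves to be no small change: the result is a 16-fold higher number from compound 2 to compound 3 (1.21 log units; beyond the scatter). This position therefore separates furan-2-yl from phenyl, not only furan-2-yl from anilino. Phenyl still outperforms anilino, with an at least 32-fold lower number from compound 1 to compound 3 (1.50 log units; beyond the scatter), but the true size of that step is unknown since compound 1 sits at a limit, not a number: the limit of > 10000 nM in this assay, at which 1 of the 3 values shown sits.

As far as these compounds go, whether the oxygen in the furan-2-yl ring is what matters remains open. Thiophen-2-yl, which carries sulfur in its place, or tetrahydrofuran-2-yl, which keeps the oxygen in a saturated ring, could help answer this.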